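The source may hold more compounds than are shown below. What is called first, only, known or untested is meant among the compounds shown, and "the series" means these compounds.

Measured so far in a functional assay on the whole organism (strain Wistar) for inhibition, with Rattus norvegicus as the target, read by paw edema, with stated times of 30 min and 3 h, at a dose of 20 mg/kg by the oral route; on this read-out lower numbers stand for less inhibition and higher numbers for more inhibition at the one dose given (going by the name of the read-out):
compound 1 `O=C(NCc1nn2c(Cc3ccccc3)nnc2s1)c1ccccc1` gives 28%;
compound 2 `c1ccc(Cc2nnc3sc(Cc4cc5ccccc5[nH]4)nn23)cc1` gives 41%;
compound 3 `O=C(NCc1nn2c(COc3ccccc3)nnc2s1)c1ccccc1` gives 37.2%.

Compound 1 and compound 3 share a core and differ in one place, (phenoxy in place of phenyl on a saturated chain carbon bound to an aromatic carbon). The change gave a number 9.2 percentage points higher from compound 1 to compound 3 (within the scatter). Compound 2 differs from compound 1 in more than one place; the difference between the two cores is not broken down here. Compound 2 reads higher than compound 1, while compound 2 and compound 3 lie within the scatter of each other.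

Compound 4 `c1ccc(OCc2nnc3sc(Cc4cc5ccccc5[nH]4)nn23)cc1` is not yet measured. It differs from compound 2 by phenoxy in place of phenyl on a saturated chain carbon bound to an aromatic carbon, the same change already seen from compound 1 to compound 3, at the same place. For compound 4 the expected step in this assay is a number 7 percentage points higher from compound 2 to compound 4 (within the scatter). This rests on the earlier step of a number 9.2 percentage points higher from compound 1 to compound 3 (within the scatter), itself within the scatter, so no larger movement is expected here. Compound 4 is estimated at 48%, most likely between 36% and 60%.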

Compound 4, a percentage reported as inhibition, in the whole organism at one dose (the size of the read-out at that dose, not a potency): 50.5%
Estimate against measurement, compound 4: 2.5 percentage points below, and the stated range covers the measured number.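

Phenoxy in place of phenyl on a saturated chain carbon bound to an aromatic carbon gives a number 9.5 percentage points higher from compound 2 to compound 4 (within the scatter) in this assay. Set beside the earlier step, the change reads alike on the two cores: the same change on two cores in this assay, a number 9.2 percentage points higher (within the scatter) from compound 1 to compound 3 and a number 9.5 percentage points higher (within the scatter) from compound 2 to compound 4, 0.3 percentage points apart, within the scatter of two such steps.
This agreement supports carrying the change from one of these two cores to the other, but each step on its own lies within the scatter, so neither establishes a real gain and the pair says nothing about further cores.

Open, on these data alone, is how anilino, with an amine in place of the oxygen of phenoxy, or a longer chain such as phenoxyethyl would read in this assay. Also open, as far as these compounds go, is whether the same step would hold at other doses.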